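A few compounds are considered here, and "the series" means these few. Any claim that something is new, unique, unknown or untested is made for them only; others in the source may bear on it.

In a functional assay on BT-474 cells (Homo sapiens) for antiproliferative activity, read by sulforhodamine B assay, with a stated time of 4 days (a lower number here means a stronger inhibitor of growth, a higher number a weaker inhibitor of growth), compound 3 (`COc1cc(Cl)c(-c2nc(SCC(=O)NC(C)C)nc3[nH]cc(C#N)c23)cc1OC`) gives 81 nM, compound 2 (`CCOc1cc(-c2nc(SCC(=O)NC(C)C)nc3[nH]cc(C#N)c23)c(Cl)cc1OC`) gives 84 nM and compound 1 (`COc1cc(Cl)c(-c2nc(SCC(=O)NC3CC3)nc3[nH]cc(C#N)c23)cc1OC`) gives 69 nM. These three values lie within the scatter of one another, so compound 3 holds no distinct rank among them.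

The next change is on the amide: compound 4 (`COc1cc(Cl)c(-c2nc(SCC(=O)N3CCC3)nc3[nH]cc(C#N)c23)cc1OC`) has azetidin-1-yl in place of isopropylamino on a carbonyl carbon. The amide hydrogen is lost, and the ring closes on the amide nitrogen.

Within the data shown here, two measured steps bear on this. The closer one is isopropyl in place of cyclopropyl on the amide-type nitrogen, a 1.2-fold higher number from compound 1 to compound 3 (0.07 log units; within the scatter). The other lies elsewhere on the molecule, hydrogen in place of methyl on a saturated chain carbon bound to an oxygen on an aromatic ring, a 1.0-fold lower number from compound 2 to compound 3 (0.02 log units; within the scatter). Neither step removes the amide hydrogen, so the series offers no direct evidence on that loss and the range has to stay wide.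

In this assay, no step beyond the scatter is expected, with only a slight lean towards a higher number. The expected change is a 1.4-fold higher number from compound 3 to compound 4 (0.13 log units; within the scatter). For compound 4 the estimated value is 110 nM, with an expected range of 45 nM to 300 nM.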

Compound 4, concentration for 50% growth inhibition: 31 nM
For compound 4 the middle estimate is 3.5-fold (0.55 log units) above the measured one, outside the stated range (below it).
By their numbers in this assay, from the lowest: compound 4; then compounds 1, 3 and 2 (each within the scatter of the next).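

In this assay, among these compounds, the substituent on the carbonyl carbon gives the first step that lies beyond the scatter: azetidin-1-yl in place of isopropylamino (a 2.6-fold lower number from compound 3 to compound 4 (0.42 log units; beyond the scatter)) and azetidin-1-yl in place of cyclopropylamino (a 2.2-fold lower number from compound 1 to compound 4 (0.35 log units; beyond the scatter)). The earlier exchange of cyclopropyl for isopropyl on the amide nitrogen kept the amide hydrogen and stayed within the scatter, whereas both new steps remove that hydrogen and close a four-membered non-aromatic ring on the nitrogen, so this position does respond to a change in the amide, though only modestly so far. Nothing measured here explains the lower number of compound 4.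

These compounds cannot separate loss of the amide hydrogen from formation of the ring: dimethylamino would lose the hydrogen without a ring, and pyrrolidin-1-yl would test a larger ring on the same carbonyl carbon. As far as these compounds go, it also remains open whether the azetidine ring tolerates a substituent such as a hydroxyl or an amine, and whether the step carries over to the ethoxy analogue, compound 2.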